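Diol to morpholine on the ether chain of compound 3

This account rests on a few compounds, and the source may have more. Where it says the series, first, only, none or still open, it means among the compounds named here.

Compound 1, `O=C(N[C@@H]1CCNC1)c1cc(-c2ccc(NS(=O)(=O)c3cccc(Cl)c3Cl)cc2)nc2[nH]ncc12`, reaches the limit of an assay for inhibition of serine/threonine-protein kinase Sgk1 (Homo sapiens), with stated times of 30 min and 60 min, in the presence of a further agent that is not named here (a higher number here means a weaker inhibitor, a lower number a stronger inhibitor), giving < 1 nM, which is a boundary rather than a number. Compound 2, `CNC(=O)c1cc(-c2ccc(NS(=O)(=O)c3cccc(Cl)c3Cl)cc2)nc2[nH]ncc12`, gives 929 nM in this assay. Compound 3, `Cc1n[nH]c2nc(-c3ccc(NS(=O)(=O)c4cc(Cl)ccc4F)cc3)nc(OCC(CO)CO)c12`, gives 2 nM and so holds the lowest of the two numbers on record; its gap to compound 2 lies beyond the scatter. The value of compound 1 is a limit and is not ordered against the two numbers. Among the compounds with values here, the one measured step, an at least 920-fold higher number from compound 1 to compound 2 (2.96 log units; beyond the scatter), shows that taking a pyrrolidin-3-yl off an amide nitrogen and leaving a methyl there costs a great deal, with the limit of < 1 nM in this assay, at which 1 of the 3 values shown sits, setting the floor from which that step is counted.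

Compound 4, `Cc1n[nH]c2nc(-c3ccc(NS(=O)(=O)c4cc(Cl)ccc4F)cc3)nc(OCC3CNCCO3)c12`, differs from compound 3 by morpholin-2-yl in place of 2-hydroxy-1-(hydroxymethyl)ethyl on a saturated chain carbon bound to an oxygen on an aromatic ring. The change brings a nitrogen-containing saturated ring into the side chain, while the measured step removed one; the two are not the same, and the only cyclic amine on record sat on an amide rather than an ether chain. With no loss to fear from the record shown, compound 4 is expected to sit close to compound 3, with a step of a 1.3-fold lower number from compound 3 to compound 4 (0.12 log units; within the scatter) no larger than the scatter and leaning toward a lower number. Compound 4 is therefore estimated at 1.5 nM in this assay, within 0.4 nM to 6 nM.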

Compound 4, half-maximal inhibitory concentration: 2 nM
Compound 4: middle estimate off by 1.3-fold (0.12 log units), on the low side; the range from low to high includes it.
By their numbers in this assay, from the lowest: compounds 3 and 4 (each within the scatter of the next); then compound 2. At a limit, below all of these: compound 1.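

With no change at the digits printed from compound 3 to compound 4 (within the scatter) in this assay, morpholin-2-yl can stand in place of 2-hydroxy-1-(hydroxymethyl)ethyl on a saturated chain carbon bound to an oxygen on an aromatic ring, and the inhibition is kept. The earlier compounds shown here showed only how much an amide substituent can matter; this pair shows a place where an open chain can give way to a six-membered non-aromatic ring, with one hydrogen-bond donor instead of two, without a change that can be read. Both compounds give true numbers rather than limits, but little room remains beneath them, so a further gain from this exchange would have been hard to see: the limit of < 1 nM in this assay, at which 1 of the 4 values shown sits.

The compounds shown leave open how a simple open-chain amine, a carboxylic acid or a longer chain ending in hydroxyl would read at this place, and whether the ring nitrogen of morpholin-2-yl contributes at all, a question that a morpholin-2-yl analogue with its nitrogen carrying a methyl or an acetyl group could address. They also leave open whether the same exchange would hold on the core of compound 1.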